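Ethyl extension on the nitro analogue: expected partition shift

This account rests on a few compounds, and the source may have more. Where it says the series, first, only, none or still open, it means among the compounds named here.

The series shares one core and varies two points: the chain on the saturated carbon bound to the core and the substituent on the outer aryl ether ring. Compound 1 `Cc1nc2ccccc2c(=O)n1/N=C/c1ccc(Oc2ccc(F)cc2)cc1` gives 4.21 in a physicochemical assay for lipophilicity, in phosphate buffer, measured as octanol-water partition; a lower number here means a more polar compound, a higher number a more lipophilic compound. Compound 2 `CCCc1nc2ccccc2c(=O)n1/N=C/c1ccc(Oc2ccc(F)cc2)cc1` carries ethyl in place of hydrogen on a saturated chain carbon bound to an aromatic carbon and gives 5.22 in this assay, a step of a number 1.01 log units higher from compound 1 to compound 2 (beyond the scatter). Compound 3 `Cc1nc2ccccc2c(=O)n1/N=C/c1ccc(Oc2ccc([N+](=O)[O-])cc2)cc1` differs from compound 1 by nitro in place of fluoro on an aromatic carbon, and in this assay compound 3 gives 4.01, a step of a number 0.20 log units lower from compound 1 to compound 3 (within the scatter), so compounds 1 and 3 are not separated here.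

Compound 4 `CCCc1nc2ccccc2c(=O)n1/N=C/c1ccc(Oc2ccc([N+](=O)[O-])cc2)cc1` has not been measured in this assay. Among the measured compounds shown here, it differs from compound 3 by ethyl in place of hydrogen on a saturated chain carbon bound to an aromatic carbon, which is the same change, made at the same place, as the one from compound 1 to compound 2. The two cores on which this change is made differ only by nitro in place of fluoro on an aromatic carbon, and that difference moved the partition coefficient within the scatter. With one measured example of the change, the expectation for compound 4 rests on that single step of a number 1.01 log units higher from compound 1 to compound 2 (beyond the scatter) carried over to compound 3.

On that basis the step from compound 3 to compound 4 is expected to be a number 0.99 log units higher from compound 3 to compound 4 (beyond the scatter) in this assay. Compound 4 is therefore estimated at 5 in this assay, with a likely range from 4.6 to 5.4, the width reflecting that the transfer rests on one pair.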

Compound 4, partition coefficient: 5.18
For compound 4 the middle estimate is 0.18 log units below the measured one; low and high end bracket the measured number.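

In this assay the change of hydrogen to ethyl on a saturated chain carbon bound to an aromatic carbon gives a number 1.17 log units higher from compound 3 to compound 4 (beyond the scatter) on the nitro core and a number 1.01 log units higher from compound 1 to compound 2 (beyond the scatter) on the fluoro core, so on these two cores the change runs the same way and both steps are large and beyond the scatter. The cross-check points the same way: a number 0.04 log units lower from compound 2 to compound 4 (within the scatter) in this assay leaves the two propyl compounds not separated, just as the two methyl compounds, compound 1 and compound 3, are not separated, so within these four compounds the chain change and the swap of nitro for fluoro read as independent of each other. This is one square of four compounds whose cores differ in a single place, so it shows no transfer to any other core and no general rule for the series, and nothing available here bears on the reason for the size of the step.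

Still open, as far as these compounds go, is whether the step keeps its size for a longer chain such as butyl or pentyl, or for a branched chain such as isopropyl. Also open, from the compounds shown here alone, is whether the chain change carries over when an amine or a carboxylic acid stands in place of fluoro or nitro on the aromatic carbon.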